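Mirror image of compound 1 in the cell assay

The compounds below may be only part of what the source reports. "The series", "measured", "known", "first", "only" and "open" are said of these compounds alone.

Measured compounds:
Compound 1 `Cc1cc(C)c(CN2CCc3c(Cl)cc([C@H](CO)[C@H]4CCCO4)c(Cl)c3C2=O)c(=O)[nH]1`: in an assay on cells for inhibition of histone-lysine N-methyltransferase EZH2 (Homo sapiens), read by ELISA, with a stated time of 72 h (a lower number here means a stronger inhibitor, a higher number a weaker inhibitor), compound 1 gives 40 nM.
Compound 2 `CCOC(c1cc(Cl)c2c(c1Cl)C(=O)N(Cc1c(C)cc(C)[nH]c1=O)CC2)C1CS(=O)(=O)C1`: in this assay compound 2 gives 6080 nM; 62 nM (2 entries).

Compound 1 stands with the only single number shown for it, and its other entry carries no single number. Compound 2 has two entries that lie far apart, so its result in this assay is uncertain.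

Compound 3 `Cc1cc(C)c(CN2CCc3c(Cl)cc([C@@H](CO)[C@@H]4CCCO4)c(Cl)c3C2=O)c(=O)[nH]1` is not yet measured. How it differs from compound 1: the two compounds have the same atoms and bonds and differ only in configuration as drawn: 2 of 2 stereo elements differ (all stereocentres are inverted: mirror images); a stereocentre at a saturated chain carbon is drawn R in compound 1 and S in compound 3; a stereocentre at a saturated ring carbon is drawn R in compound 1 and S in compound 3.

Among the compounds with values here, no step between measured compounds is available, so the size of this step rests on the structural change alone and on the spread seen for compound 2. Because the several entries of compound 2 in this assay, 6080 nM; 62 nM (2 entries) shows two entries for one structure far beyond the scatter, a change of configuration may well be expected to shift this assay strongly. Compound 3 is therefore expected to be weaker, with a step estimated at a 38-fold higher number from compound 1 to compound 3 (1.57 log units; beyond the scatter), though the direction is uncertain. Compound 3 is estimated at 1500 nM, with a range from 60 nM to 20000 nM.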

Compound 3, half-maximal inhibitory concentration: 1570 nM
The estimate for compound 3 lay 1.0-fold (0.02 log units) below the measured number; the measured number falls inside the stated range.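

In this assay, the change from one mirror image to the other gives a 39-fold higher number from compound 1 to compound 3 (1.59 log units; beyond the scatter), so compound 1 is clearly the stronger of the pair. Within the data shown here, this is the first clean reading of configuration at this position, and it shows that the arrangement in space of the substituent on the shared core matters greatly in this assay, since the whole step comes from configuration alone: the fact that compounds 1 and 3 differ only in the configuration as drawn. The earlier compounds shown here could only hint at such sensitivity, and that hint came from one structure whose results disagree and which offers no partner differing in one place: the several entries of compound 2 in this assay, 6080 nM; 62 nM (2 entries).

The compounds shown leave open which of the two stereocentres, the saturated chain carbon or the saturated ring carbon, accounts for the step, as both are inverted together and the share of each stays unknown. They also leave open how a chain carrying an amine or a carboxylic acid would fare in this assay, and whether the same preference for one configuration would hold there.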